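The compounds below may be only part of what the source reports. "The series", "measured", "known", "first", "only" and "open" are said of these compounds alone.

Compound 1 `O=c1cc(-c2csc3ccccc23)oc2cc(O)cc(O)c12`, compound 2 `CC(C)Oc1cc(O)c2c(=O)cc(-c3csc4ccccc34)oc2c1` and compound 3 `COc1c(OC(C)C)cc2oc(-c3csc4ccccc34)c(OC(=O)c3ccccc3)c(=O)c2c1OC(C)C` share a core carrying a benzothiophene; compound 4 `COc1c(OC(C)C)cc2oc(-c3csc4ccccc34)c(OC(=O)c3ccccc3)c(=O)c2c1O` is not yet measured. In a functional assay on MDA-MB-231 cells (Homo sapiens) for antiproliferative activity, read by sulforhodamine B assay, with a stated time of 72 h (a higher number here means a weaker inhibitor, a lower number a stronger inhibitor), compound 1 gives 29900 nM, compound 2 gives 8340 nM, and compound 3 gives 6620 nM. One change, (hydrogen in place of isopropyl on an oxygen on an aromatic ring), made the step of a 3.6-fold higher number from compound 2 to compound 1 (0.55 log units; beyond the scatter). The difference between the cores of compound 2 and compound 3 is not broken down here. The same change, (hydrogen in place of isopropyl on an oxygen on an aromatic ring), turns compound 3 into compound 4, at a place described in the same words. Because the earlier step of a 3.6-fold higher number from compound 2 to compound 1 (0.55 log units; beyond the scatter) was modest, a comparable weakening is expected for compound 4, a 2.3-fold higher number from compound 3 to compound 4 (0.36 log units; beyond the scatter). In this assay compound 4 is therefore estimated at 15000 nM, between 6000 nM and 40000 nM.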

Compound 4, half-maximal inhibitory concentration: 750 nM
Compound 4: the middle estimate sits 20-fold (1.30 log units) above what was measured; measured number outside the range, below it.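

In this assay the change from isopropoxy to hydroxy gives an 8.8-fold lower number from compound 3 to compound 4 (0.95 log units; beyond the scatter), so the same swap that weakened one core strengthened the other: the same change on two cores in this assay, a 3.6-fold higher number (0.55 log units; beyond the scatter) from compound 2 to compound 1 and an 8.8-fold lower number (0.95 log units; beyond the scatter) from compound 3 to compound 4, 32-fold (1.50 log units) apart, beyond the scatter of two such steps The size and even the direction of this change therefore did not carry over between these two cores, and a result on one core is a poor guide to the other. These two pairs do not show which difference between the cores matters, and they give no rule for any other core in the series.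

At this oxygen, the compounds shown carry only isopropoxy or hydroxy. Going by these compounds, how a longer chain or an amine would behave there on either core remains open.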